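The compounds below may be only part of what the source reports. "The series", "measured", "known", "first", "only" and "open" are said of these compounds alone.

Compound 1, `Cc1ncnc2c1c(-c1cc3ccccc3o1)cn2[C@@H]1O[C@H](CO)[C@@H](O)[C@H]1O`, was tested in a functional assay on HCT-116 cells (Homo sapiens), read by MTT assay, with a stated time of 72 h (on this read-out lower numbers stand for stronger inhibition and higher numbers for weaker inhibition), where compound 1 gave only a limit of > 20000 nM. Two other compounds carry numbers in this assay: compound 2, `O=c1[nH]cnc2c1c(-c1ccco1)cn2[C@@H]1O[C@H](CO)[C@@H](O)[C@H]1O`, and compound 3, `C#Cc1cn([C@@H]2O[C@H](CO)[C@@H](O)[C@H]2O)c2nc(C)nc(N)c12`. In this assay compound 2 likewise reached only the limit of > 20000 nM. In this assay compound 3 also stopped at the limit of > 20000 nM. Compound 1 therefore sits exactly where every measured compound sits, as the limit of > 20000 nM in this assay, at which 3 of the 3 values shown sit, shows; no order among the three can be read from these values, and nothing beyond the limit is known for any of them.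

Compound 4, `Cc1ncnc2c1c(-c1cccs1)cn2[C@@H]1O[C@H](CO)[C@@H](O)[C@H]1O`, differs from compound 1 in one place: thiophen-2-yl in place of 1-benzofuran-2-yl on an aromatic carbon. Within the data shown here, no step between two measured compounds is available, so the size of this kind of change cannot be read from any pair here. Compound 1 and the other measured compounds all sit at the limit in this assay, and compound 4 is expected to stay in the same region, with the expected step that the limit leaves unreadable from compound 1 to compound 4 amounting to none beyond the scatter in either direction. The estimate for compound 4 in this assay is 30000 nM, within a range from 10000 nM to 100000 nM.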

Compound 4, half-maximal inhibitory concentration: > 20000 nM
Compound 4: a limit, no number; the forecaster's own chance of this, stated with the estimate: 85%; the middle value lies beyond the limit too.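

In this assay compound 4 gave only a limit, > 20000 nM. Among these compounds, compound 1 also carries only a limit, so no step from compound 1 to compound 4 can be read. The compounds shown leave open any order among them and what thiophen-2-yl in place of 1-benzofuran-2-yl does, because all share one value: the limit of > 20000 nM in this assay, at which 4 of the 4 values shown sit.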